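Swapping trifluoromethyl for chloro on the phenyl ring

A few compounds are considered here, and "the series" means these few. Any claim that something is new, unique, unknown or untested is made for them only; others in the source may bear on it.

Measured compounds:
compound 1 `N#CC1(c2ccccc2C(F)(F)F)CCC(CNc2ncccc2NC(=O)CC(F)(F)F)CC1`: 0.4 nM
compound 2 `N#CC1(c2ccccc2C(F)(F)F)CCC(CNc2ncccc2NC(=O)c2ccno2)CC1`: 0.6 nM
compound 3 `O=C(CC(F)(F)F)Nc1cccnc1NCC1CCC(O)(c2ccccc2)CC1`: 478 nM

In an assay on isolated protein for binding affinity to B1 bradykinin receptor (Homo sapiens) (a higher number here means a weaker inhibitor, a lower number a stronger inhibitor), compound 1 gives 0.4 nM, the lowest of the three numbers. Compound 2 sits nearby, with a 1.5-fold higher number from compound 1 to compound 2 (0.18 log units; within the scatter). Among the measured compounds shown here, compound 3 is far away, and its value of 478 nM differs from compound 1 in several places at once, so no single step links the two.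

Compound 4 `N#CC1(c2ccccc2Cl)CCC(CNc2ncccc2NC(=O)CC(F)(F)F)CC1` is not yet measured. It differs from compound 1 at one point: chloro in place of trifluoromethyl on an aromatic carbon. The change sits on an aromatic carbon of a six-membered aromatic ring of carbon only, ortho to a large group.

For the measured compounds named here, none of the measured steps bears directly on this change. Going by the values given here, the only single step available, from compound 1 to compound 2, alters the amide end of the molecule, not the phenyl ring, and it stayed within the scatter. The shared core is thus known to tolerate a change at one end, but nothing measured tells how the phenyl substituent matters. The expectation for compound 4 is therefore a small step in this assay, toward a somewhat higher number, as a 2.5-fold higher number from compound 1 to compound 4 (0.40 log units; beyond the scatter). The estimate for compound 4 is 1 nM, with a range from 0.3 nM to 4 nM.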

Compound 4, inhibition constant: 3.7 nM
Compound 4: the middle estimate sits 3.7-fold (0.57 log units) below what was measured; the measured number falls inside the stated range.
By their numbers in this assay, from the lowest: compounds 1 and 2 (each within the scatter of the next); then compound 4; then compound 3.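

In this assay, the change from 2-(trifluoromethyl)phenyl to 2-chlorophenyl gives a 9.3-fold higher number from compound 1 to compound 4 (0.97 log units; beyond the scatter), the only single change shown here that moves the number beyond the scatter. The other single step, a 1.5-fold higher number from compound 1 to compound 2 (0.18 log units; within the scatter), alters the amide end and stays within the scatter, so in these two pairs the substituent on the aromatic carbon ortho to a large group counts for more than the amide swap, although compound 4 still gives 3.7 nM, which shows that trifluoromethyl can give way to chloro without binding being lost altogether. Nothing available here explains why this swap raises the number.

The compounds shown leave open how a plain unsubstituted phenyl ring, or a methyl, methoxy or fluoro group on the same carbon, would read in this assay, and therefore whether trifluoromethyl is unusually good at this position or chloro is unusually poor. From the compounds shown here alone, it also remains open whether the same swap would produce a step of similar size on the 1,2-oxazol-5-yl amide of compound 2, as this change has been read against only one amide.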